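The source may report more compounds than this note shows. Statements on the series, on what has been measured and on what is new or still open speak of the compounds shown alone.

Measured compounds in a functional assay on MCF7 cells (Homo sapiens) for inhibition, read by MTT assay, with a stated time of 72 h; on this read-out lower numbers stand for stronger inhibition of growth and higher numbers for weaker inhibition of growth:

Compound 1, `O=S(=O)(NCCNCc1ccc(-c2ccccc2)cc1)c1cc(C(F)(F)F)cc(C(F)(F)F)c1`, gives 1400 nM.
Compound 2, `O=S(=O)(NCCCNCc1ccc(Cl)c(C(F)(F)F)c1)c1cc(C(F)(F)F)cc(C(F)(F)F)c1`, gives 3500 nM.
Compound 3, `CC(C)(C)c1ccc(CNCCNS(=O)(=O)c2cc(C(F)(F)F)cc(C(F)(F)F)c2)cc1`, gives 13000 nM.

Among these three, compound 2 gives the second highest number. Its nearest neighbour is compound 1, whose number is lower, and the furthest is compound 3, whose number is higher; both of these gaps lie beyond the scatter. Compound 2 differs from compound 1 in more than one place, so only the two values themselves can be compared.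

Compound 4, `COc1cccc(CNCCCNS(=O)(=O)c2cc(C(F)(F)F)cc(C(F)(F)F)c2)c1`, has not yet been measured in this assay. It differs from compound 2 in one place: 3-methoxyphenyl in place of 4-chloro-3-(trifluoromethyl)phenyl on a saturated chain carbon bound to an amine nitrogen.

Among the measured compounds shown here, the only single-point step measured so far is a 9.3-fold higher number from compound 1 to compound 3 (0.97 log units; beyond the scatter), which changes a group on an aromatic carbon rather than swapping the whole aryl group on the chain carbon, so it bears only loosely on the present change. For the measured compounds named here, no measured pair shows what exchanging a 4-chloro-3-(trifluoromethyl)phenyl for a 3-methoxyphenyl does. Given that the one measured step was modest, the step of a 1.3-fold higher number from compound 2 to compound 4 (0.11 log units; within the scatter) is expected to be modest as well, in either direction. Compound 4 is therefore estimated to give 4500 nM, within the range 1500 nM to 14000 nM.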

Compound 4, concentration for 50% growth inhibition: 2400 nM
Compound 4: middle estimate off by 1.9-fold (0.27 log units), on the high side, within the range that was stated.
By their numbers in this assay, from the lowest: compounds 1, 4 and 2 (each within the scatter of the next, the first and the last beyond it); then compound 3.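

In this assay, among the compounds shown here, exchanging the aryl group on a saturated chain carbon bound to an amine nitrogen gives a 1.5-fold lower number from compound 2 to compound 4 (0.16 log units; within the scatter), the first measured step in which the whole aryl group is replaced. Here, this assay does not separate 3-methoxyphenyl from 4-chloro-3-(trifluoromethyl)phenyl, even though the entering group has fewer heavy atoms than the group it replaces, has one hydrogen-bond acceptor rather than none, and carries oxygen in place of chlorine and fluorine. No measurement offered here explains why the two groups read alike.

The exchange alters several parts of the aryl group at once, so the compounds shown leave open what the chloro, trifluoromethyl and methoxy groups each contribute alone, and whether a carboxylic acid or a nitrile on the ring would also read alike. They also leave open whether 3-methoxyphenyl would behave in the same way on the chain of compound 1 and compound 3, or on a longer chain than that of compound 2 and compound 4.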